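Swapping the Aryl Group on a Shared Core

The source may report more compounds than this note shows. Statements on the series, on what has been measured and on what is new or still open speak of the compounds shown alone.

Of the compounds shown here, three that share one core have been tested in a functional assay on A549 cells (Homo sapiens) for inhibition, read by sulforhodamine B assay, with a stated time of 48 h, tested at 10 uM; a lower number here means less inhibition, a higher number more inhibition at the concentration tested (going by the name of the read-out). Compound 1, `c1ccc(-c2cn3ccnc3c(-c3ccc4ncn(C5CCCCC5)c4c3)n2)cc1`, carries an unsubstituted phenyl group and gives 33.3%. Compound 2, `COc1ccc(-c2cn3ccnc3c(-c3ccc4ncn(C5CCCCC5)c4c3)n2)cc1`, gives 68.6%, and compound 3, `Clc1ccc(-c2cn3ccnc3c(-c3ccc4ncn(C5CCCCC5)c4c3)n2)cc1`, gives 11.6%. Compound 2 thus stands highest of the three: the step of a number 35.3 percentage points higher from compound 1 to compound 2 (beyond the scatter) and the step of a number 57 percentage points lower from compound 2 to compound 3 (beyond the scatter) both lie beyond the scatter, so its lead over compound 1 and over compound 3 is real.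

Compound 4, `Fc1ccccc1-c1cn2ccnc2c(-c2ccc3ncn(C4CCCCC4)c3c2)n1`, is not yet measured. The change from compound 2 is 2-fluorophenyl in place of 4-methoxyphenyl on an aromatic carbon. For the measured compounds named here, two measured steps bear on it. Removing the methoxy group, seen in reverse as a number 35.3 percentage points higher from compound 1 to compound 2 (beyond the scatter), cost a large amount, and putting chloro where methoxy stood, the step of a number 57 percentage points lower from compound 2 to compound 3 (beyond the scatter), cost even more. Going by the values given here, no measured step puts a 2-fluorophenyl on the core, so its exact effect is unknown, but both comparisons show that compound 2 owes its high number to the methoxy group, which compound 4 loses. A sizeable fall is therefore expected, as the step of a number 40.6 percentage points lower from compound 2 to compound 4 (beyond the scatter). Compound 4 is estimated at 28% in this assay, within a range from 8% to 50%.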

Compound 4, a percentage reported as inhibition, at one concentration (the size of the read-out at that concentration, not a potency): 9.1%
For compound 4 the middle estimate is 18.9 percentage points above the measured one, within the range that was stated.
By their numbers in this assay, from the lowest: compounds 4 and 3 (each within the scatter of the next); then compound 1; then compound 2.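

Swapping the 4-chlorophenyl group for 2-fluorophenyl makes no difference that can be told apart in this assay (a number 2.5 percentage points lower from compound 3 to compound 4 (within the scatter)), so two phenyl groups carrying different halogens on different ring carbons read alike here. Fluoro in place of hydrogen on the plain phenyl group gives a modest step (a number 24.2 percentage points lower from compound 1 to compound 4 (beyond the scatter)), and together with compound 3 this places both halogen-bearing groups under the unsubstituted phenyl group, while only the 4-methoxyphenyl group of compound 2 rises above it. The large step for 2-fluorophenyl in place of 4-methoxyphenyl (a number 59.5 percentage points lower from compound 2 to compound 4 (beyond the scatter)) shows that the lead of compound 2 disappears with a second halogen-bearing group as well, not with chloro alone.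

From the compounds shown here alone, it remains open how an amine or a longer ether chain such as ethoxy on the phenyl group would compare with the methoxy group of compound 2, and whether fluoro and chloro would still read alike on the same ring carbon. Nothing given here offers an explanation for why these aryl groups give such different numbers.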